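Replacing the 1-methyl-1H-pyrazol-3-yl group of compound 1

The source may report more compounds than this note shows. Statements on the series, on what has been measured and on what is new or still open speak of the compounds shown alone.

Compound 1 `C=CC(=O)Nc1cccc(Oc2nc(Nc3ccn(C)n3)nc3c2CSCC3)c1`: > 50000 nM
Compound 2 `CCC/C=C/C(=O)Nc1cccc(Oc2nc(Nc3ccn(C)n3)nc3c2CSCC3)c1`: > 50000 nM
Compound 3 `CC(C)=CC(=O)Nc1cccc(Oc2nc(Nc3ccn(C)n3)nc3c2CSCC3)c1`: > 50000 nM

In an ADME assay on L02 cells (Homo sapiens) for cytotoxicity, read by MTT assay, with a stated time of 72 h (a higher number here means a weaker inhibitor, a lower number a stronger inhibitor), compound 1 gives > 50000 nM, which is a limit and not a number. It shares with compound 2 and compound 3 (the limit of > 50000 nM in this assay, at which 3 of the 3 values shown sit).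

Compound 4 `C=CC(=O)Nc1cccc(Oc2nc(Nc3cccc(OC)c3)nc3c2CSCC3)c1` differs from compound 1 in another place: 3-methoxyphenyl in place of 1-methyl-1H-pyrazol-3-yl on a nitrogen on an aromatic ring. The measured steps, a step that the two limits leave unreadable from compound 1 to compound 2, a step that the two limits leave unreadable from compound 1 to compound 3 and a step that the two limits leave unreadable from compound 2 to compound 3, change only the group on the carbonyl carbon, so they offer no size to carry over. A modest move towards stronger inhibition is expected, an at least 1.2-fold lower number from compound 1 to compound 4 (0.09 log units; that floor lies within the scatter), though another limit is about equally likely. For compound 4 the estimate is 40000 nM, with an expected range of 12000 nM to 80000 nM.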

Compound 4, half-maximal inhibitory concentration: 48900 nM
Compound 4: the middle estimate sits 1.2-fold (0.09 log units) below what was measured; the measured number falls inside the stated range.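

With 3-methoxyphenyl in place of 1-methyl-1H-pyrazol-3-yl, compound 4 is the only compound shown that gives a true number in this assay. The swap gives an at least 1.0-fold lower number from compound 1 to compound 4 (0.00 log units; that floor lies within the scatter), so no real change can be claimed for this place on the nitrogen. Compound 1 remains a limit, so the true size of the step stays unknown: the limit of > 50000 nM in this assay, at which 3 of the 4 values shown sit.

Still open, as far as these compounds go, is how a phenyl ring carrying an amine such as piperazine would read at this nitrogen. Also open, from the compounds shown here alone, is whether any group here brings the number far lower.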